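Swapping an Ether Side Chain for a Terminal Alkene

The source may report more compounds than this note shows. Statements on the series, on what has been measured and on what is new or still open speak of the compounds shown alone.

Compound 1 `COCCCn1c(Cc2cc(OC)c(OC)c(OC)c2)nc2c(N)nc(F)nc21`: 72600000 nM
Compound 2 `COc1cc(Cc2nc3c(N)nc(F)nc3n2CCOC(C)C)cc(OC)c1OC`: 769000000 nM

Both compounds share one core and differ only in the chain attached to the aromatic nitrogen. In a functional assay on MCF7 cells (Homo sapiens) for cytotoxicity (a lower number here means that less compound is needed, a higher number that more compound is needed for the effect), compound 1 gives 72600000 nM, and compound 2 gives 769000000 nM. Among the compounds with values here, compound 2 therefore stands highest of the two numbers, and the single measured step, an 11-fold higher number from compound 1 to compound 2 (1.02 log units; beyond the scatter), is large and beyond the scatter.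

Compound 3 `C=CCCn1c(Cc2cc(OC)c(OC)c(OC)c2)nc2c(N)nc(F)nc21` takes the next step: vinyl in place of isopropoxy on a saturated chain carbon, two bonds along the chain from an aromatic nitrogen. Within the data shown here, the one measured step bears on this only indirectly: it shows that altering the substituent on this chain carbon can shift the number a great deal, from a smaller ether to a bulkier one. Among the measured compounds shown here, compound 3 removes the ether oxygen altogether and carries a small vinyl instead; no measured pair covers such a change, so the direction is uncertain. Since the smaller substituent of compound 1 gave the lower number 72600000 nM, compound 3 is expected to move back toward that level, a step of a 5.1-fold lower number from compound 2 to compound 3 (0.71 log units; beyond the scatter). The estimate for compound 3 is 150000000 nM, within a range from 30000000 nM to 800000000 nM.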

Compound 3, half-maximal effective concentration: 102000000 nM
For compound 3 the middle estimate is 1.5-fold (0.17 log units) above the measured one; measured number inside the range.
By their numbers in this assay, from the lowest: compounds 1 and 3 (each within the scatter of the next); then compound 2.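

In this assay, vinyl in place of isopropoxy gives a 7.5-fold lower number from compound 2 to compound 3 (0.88 log units; beyond the scatter) and so undoes most of the rise seen with isopropoxy, which shows that the high number of compound 2 is not fixed by the shared core and depends on the group at this chain carbon. Vinyl in place of methoxymethyl gives a 1.4-fold higher number from compound 1 to compound 3 (0.15 log units; within the scatter) and so leaves compound 1 and compound 3 at one level, even though vinyl holds only carbon, which means an ether oxygen at this place is not required for that level. No measurement offered here explains why isopropoxy stands apart from the other two groups.

Isopropoxy differs from methoxymethyl and from vinyl in more than one way, so a branched carbon group such as tert-butyl or an unbranched ether such as ethoxymethyl would be needed to tell whether the branching or the oxygen goes with the higher number. As far as these compounds go, how an amine, a carboxylic acid or a longer carbon chain would behave on this saturated chain carbon also remains open.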